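Sulfonate ester series: acetamido to cyclopropylurea on compound 3

The source may report more compounds than this note shows. Statements on the series, on what has been measured and on what is new or still open speak of the compounds shown alone.

Measured in a functional assay on M21 cells (Homo sapiens) for antiproliferative activity, read by sulforhodamine B assay, with a stated time of 48 h; a higher number here means a weaker inhibitor, a lower number a stronger inhibitor:
compound 1 `CCCC(=O)Nc1cccc(S(=O)(=O)Oc2ccccc2C(C)C)c1` gives 20000 nM
compound 2 `CC(=O)Nc1ccc(S(=O)(=O)Oc2ccccc2C(C)C)cc1` gives 21000 nM
compound 3 `CC(=O)Nc1ccc(S(=O)(=O)Oc2ccccc2I)cc1` gives 27000 nM

Among the compounds with values here, compound 3 has the highest of the three numbers, but its gaps to compound 2 and compound 1 both sit within the scatter; the one single-point step recorded, a 1.3-fold higher number from compound 2 to compound 3 (0.11 log units; within the scatter), shows the same. Compound 4 `O=C(Nc1ccc(S(=O)(=O)Oc2ccccc2I)cc1)NC1CC1` differs from compound 3 by cyclopropylamino in place of methyl on a carbonyl carbon. Within the data shown here, no measured pair changes the acetyl carbon, so nothing among the recorded steps bears on this move; the only comparison available, iodo for isopropyl, did not shift this assay. With no support for a shift either way, compound 4 is expected to stay near compound 3, an estimated step of a 1.1-fold lower number from compound 3 to compound 4 (0.03 log units; within the scatter). The estimate for compound 4 in this assay is 25000 nM, in the range 8000 nM to 80000 nM.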

Compound 4, half-maximal inhibitory concentration: 11000 nM
Compound 4: middle estimate off by 2.3-fold (0.36 log units), on the high side, and the stated range covers the measured number.
By their numbers in this assay, from the lowest: compounds 4, 1, 2 and 3 (each within the scatter of the next, the first and the last beyond it).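

Cyclopropylamino in place of methyl on the carbonyl carbon is the first single-point change in the series to move this assay beyond the scatter (a 2.5-fold lower number from compound 3 to compound 4 (0.39 log units; beyond the scatter)), a modest step. The position therefore accepts the larger group, with its three-membered ring and hydrogen-bond donor, and the number falls rather than rises. Nothing measured here accounts for the shift.

As far as these compounds go, whether the ring or the added nitrogen carries the step remains open. A plain amino or methylamino group on the same carbonyl carbon would separate the two.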